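This account rests on a few compounds, and the source may have more. Where it says the series, first, only, none or still open, it means among the compounds named here.

The measured compounds in a functional assay on MIA PaCa-2 cells (Homo sapiens) for inhibition, read by MTT assay, with a stated time of 3 days (on this read-out higher numbers stand for weaker inhibition and lower numbers for stronger inhibition), are:

Compound 1 `CCOC(=O)[C@@H]1CCC[C@@H](S(=O)(=O)c2ccc(S(=O)(=O)N(CC)CC)cc2)C1` gives 5000 nM.
Compound 2 `CCN(CC)S(=O)(=O)c1ccc(S(=O)(=O)N2CCC[C@@H](C(=O)N3CCN(c4nc(C(F)(F)F)no4)CC3)C2)cc1` gives 60 nM.
Compound 3 `CC(C)c1noc(N2CCN(C(=O)[C@@H]3CCCN(S(=O)(=O)c4ccc(S(=O)(=O)C5CCC5)cc4)C3)CC2)n1` gives 20 nM.

Among these three numbers compound 3 stands lowest. Its nearest neighbour is compound 2, whose number is higher by an amount beyond the scatter, and compound 1 lies far above both. Within the data shown here, no two of the measured compounds differ in a single place, so no single step between measured compounds can be read off, and the ranking rests on the three values alone.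

Compound 4 `CC(C)c1noc(N2CCN(C(=O)[C@@H]3CCCN(S(=O)(=O)c4ccc(S(=O)(=O)NC(C)(C)C)cc4)C3)CC2)n1` is the next compound and has not yet been measured in this assay. It differs from compound 3 in one place: (tert-butyl)amino in place of cyclobutyl on a sulfonyl sulfur. Nothing measured isolates this change, so the expectation for compound 4 leans on the standing of compound 3 and on the fact that all three measured compounds share the rest of the scaffold.

The step from compound 3 to compound 4 is expected to be small, most likely a modest rise in the number and possibly none beyond the scatter, as a 2.0-fold higher number from compound 3 to compound 4 (0.30 log units; within the scatter). Compound 4 is therefore estimated at 40 nM in this assay, within a range from 10 nM to 160 nM.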

Compound 4, half-maximal inhibitory concentration: 100 nM
For compound 4 the middle estimate is 2.5-fold (0.40 log units) below the measured one, and the stated range covers the measured number.
By their numbers in this assay, from the lowest: compound 3; then compounds 2 and 4 (each within the scatter of the next); then compound 1.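

In this assay the swap of cyclobutyl for (tert-butyl)amino on a sulfonyl sulfur gives a 5.0-fold higher number from compound 3 to compound 4 (0.70 log units; beyond the scatter) and is the only single-place step among the compounds shown, so it is the first direct sign that the group on this sulfur affects the number. The step is modest, and with this open-chain group in place compound 4 still gives 100 nM on the same read-out, so inhibition in the nanomolar range survives the loss of the four-membered carbon ring and the arrival of a nitrogen with its hydrogen-bond donor. Nothing available explains the rise in the number.

The change alters the ring, the nitrogen and the donor count together, so a cyclobutylamino group or a tert-butyl group bonded directly to the same sulfur would be needed to separate these contributions. From the compounds shown here alone, it also remains open how a smaller group such as methyl, or a ring-bearing amine such as morpholine, would fare at this sulfur.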